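A few compounds are considered here, and "the series" means these few. Any claim that something is new, unique, unknown or untested is made for them only; others in the source may bear on it.

Measured so far in an assay on Prostate gland for inhibition of steroid 5-alpha-reductase (Rattus norvegicus); on this read-out higher numbers stand for weaker inhibition and lower numbers for stronger inhibition:
compound 1 `CCCn1ccc2cc(/C(C)=C/C(=O)Nc3ccccc3OCCCC(=O)O)ccc21` — 190 nM
compound 2 `C/C(=C\C(=O)Nc1ccccc1OCCCC(=O)O)c1ccc2c(ccn2Cc2ccc(C(C)(C)C)cc2)c1` — 170 nM

Compound 2 stands at the lower of the two numbers, but its gap to compound 1 is within the scatter, so the two cannot be ordered. Going by the values given here, the one measured step, a 1.1-fold lower number from compound 1 to compound 2 (0.05 log units; within the scatter), shows that a substantial enlargement of the group on the aromatic nitrogen left the read-out essentially unchanged.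

Compound 3 `C/C(=C\C(=O)Nc1ccccc1OCCCC(=O)O)c1ccc2c(ccn2C(CC(C)C)c2ccccc2)c1` differs from compound 2 by 3-methyl-1-phenylbutyl in place of 4-(tert-butyl)benzyl on an aromatic nitrogen; the two have the same atoms, joined differently. Among the compounds with values here, no measured step covers this particular rearrangement. Within the data shown here, the only bearing information is the step from compound 1 to compound 2, which was within the scatter despite a larger change at the same nitrogen, so no step beyond the scatter is expected in this assay. The expected step of no change at the digits printed from compound 2 to compound 3 (within the scatter) is therefore close to nil. Compound 3 is estimated at 170 nM, with a range of 60 nM to 500 nM.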

Compound 3, half-maximal inhibitory concentration: 6.3 nM
The estimate for compound 3 lay 27-fold (1.43 log units) above the measured number; the whole stated range lies above it.
By their numbers in this assay, from the lowest: compound 3; then compounds 2 and 1 (each within the scatter of the next).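

In this assay, the group on the aromatic nitrogen proves able to move the read-out strongly: exchanging 4-(tert-butyl)benzyl for 3-methyl-1-phenylbutyl gives a 27-fold lower number from compound 2 to compound 3 (1.43 log units; beyond the scatter), although the two groups have the same computed counts. Set against propyl, 3-methyl-1-phenylbutyl gives a 30-fold lower number from compound 1 to compound 3 (1.48 log units; beyond the scatter), so the within-scatter result for 4-(tert-butyl)benzyl does not hold for every large group at this position, and the arrangement of the atoms matters here, not just their number. No supporting measurement is available to explain this difference.

Going by these compounds, it remains open whether the phenyl or the 2-methylpropyl part of 3-methyl-1-phenylbutyl carries the step; benzyl or 3-methylbutyl on the aromatic nitrogen would separate the two. Also open, on these data alone, is whether the two mirror-image forms of compound 3 share its number.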